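The source may hold more compounds than are shown below. What is called first, only, known or untested is meant among the compounds shown, and "the series" means these compounds.

Compound 1 `C=CC1=C(C(=O)Nc2ccccc2OC)C(c2ccc(F)cc2)OC1`: in a functional assay on HeLa cells (Homo sapiens) for cytotoxicity, read by MTT assay, with a stated time of 24 h (on this read-out lower numbers stand for stronger inhibition and higher numbers for weaker inhibition), only a limit, > 100000 nM.
Compound 2 `C=CC1=C(C(=O)NCc2ccccc2F)C(c2ccc(F)cc2)OC1`: in this assay only a limit, > 100000 nM.
Compound 3 `C=CC1=C(C(=O)NCc2ccccc2F)C(c2ccc(OC)cc2)OC1`: in this assay only a limit, > 100000 nM.

All three values sit at the limit of > 100000 nM in this assay, at which 3 of the 3 values shown sit, so none of them is a number. The change from compound 2 to compound 3 is methoxy in place of fluoro on an aromatic carbon, and its step is a step that the two limits leave unreadable from compound 2 to compound 3. The change from compound 2 to compound 1 is 2-methoxyphenyl in place of 2-fluorobenzyl on an amide-type nitrogen, with the step that the two limits leave unreadable from compound 2 to compound 1. Compound 4 `C=CC1=C(C(=O)Nc2ccccc2OC)C(c2ccc(OC)cc2)OC1` has not yet been measured; it differs from compound 3 by 2-methoxyphenyl in place of 2-fluorobenzyl on an amide-type nitrogen, which is the same change, at the same place, as that from compound 2 to compound 1. Because every value sits at the limit of > 100000 nM in this assay, at which 3 of the 3 values shown sit, the earlier step has no readable size, and the step is expected to be a step that the limit leaves unreadable from compound 3 to compound 4, most likely again ending at a limit. In this assay compound 4 is therefore estimated at 150000 nM.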

Compound 4, half-maximal inhibitory concentration: > 100000 nM
Compound 4: only a limit was reported; the forecaster's own chance of this, stated with the estimate: 85%; the middle value lies beyond the limit too.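

In this assay compound 4 gives only a limit, > 100000 nM. Its steps from compound 1 and from compound 3 cannot be read. The compounds shown leave open whether either change alters cytotoxicity at all: the limit of > 100000 nM in this assay, at which 4 of the 4 values shown sit.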